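The source may hold more compounds than are shown below. What is called first, only, known or untested is meant among the compounds shown, and "the series" means these compounds.

Measured compounds:
compound 1 `CC(C)(C)Cc1c(-c2ccccn2)sc(N)c1C(=O)c1ccc(Cl)cc1`: 1%
compound 2 `CC(C)c1ccc(-c2sc(N)c(C(=O)c3ccc(Cl)cc3)c2CC(C)(C)C)cc1`: 1%

Both values come from an assay on CHO cells for displacement of a labelled ligand from adenosine receptor A3 (Homo sapiens), read by scintillation counting, tested at 10 uM; a lower number here means less inhibition, a higher number more inhibition at the concentration tested (going by the name of the read-out). Among the compounds with values here, compound 2 stands level with compound 1 at the digits recorded; the only measured step, no change at the digits printed from compound 1 to compound 2 (within the scatter), lies within the scatter. Compound 3 is `CC(C)(C)Cc1c(-c2ccsc2)sc(N)c1C(=O)c1ccc(Cl)cc1`, not yet measured. It differs from compound 2 by thiophen-3-yl in place of 4-isopropylphenyl on an aromatic carbon. Within the data shown here, the one measured step that bears on this change is no change at the digits printed from compound 1 to compound 2 (within the scatter), which exchanged one aromatic group for another on the same aromatic carbon of the shared core without moving the read-out beyond the scatter. On that basis a further exchange of the aromatic group on that carbon in compound 3 is expected to give a step of a number 2 percentage points higher from compound 2 to compound 3 (within the scatter), that is, none beyond the scatter. Two compounds give a narrow footing, and nothing in the data shows whether thiophen-3-yl behaves as pyridin-2-yl and 4-isopropylphenyl did. Compound 3 is therefore estimated at 3%, with a range from -8% to 15%.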

Compound 3, a percentage reported as inhibition, at one concentration (the size of the read-out at that concentration, not a potency): 4%
The estimate for compound 3 lay 1 percentage points below the measured number; the measured number falls inside the stated range.
By their numbers in this assay, from the lowest: compounds 1, 2 and 3 (each within the scatter of the next).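

In this assay the carbon next to the ring sulfur now carries a third aromatic group, with a number 3 percentage points higher from compound 2 to compound 3 (within the scatter) and a number 3 percentage points higher from compound 1 to compound 3 (within the scatter) as the two steps. The earlier pair covered only six-membered aromatic rings, whereas thiophen-3-yl is a five-membered aromatic ring with 1 hetero atom and 5 heavy atoms, against the 9 heavy atoms of 4-isopropylphenyl, so among these three compounds neither that ring change nor that difference in heavy atoms appears as a step beyond the scatter. Nothing measured alongside these numbers speaks to why the read-out holds level across these aromatic groups.

On these data alone, all three compounds carry an aromatic ring at this carbon, so whether an amine, a carboxylic acid or a longer chain there would give a step beyond the scatter remains open. As far as these compounds go, the neopentyl group, the amino group and the (4-chlorophenyl)carbonyl group are common to all three compounds, so what changes at those places would do to the read-out also remains open.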